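Furan Ketone to Isopropyl Amide on a Bicyclic Amine

This account rests on a few compounds, and the source may have more. Where it says the series, first, only, none or still open, it means among the compounds named here.

Compound 1 `O=C(c1ccco1)[C@H]1C[C@H]2CNC[C@H]2C1`: 94%
Compound 2 `O=C(c1ccco1)[C@H]1C[C@@H]2CNC[C@@H](C2)C1`: "not determined" (no result reported)

Two compounds carry the furan-2-yl ketone on a saturated bicyclic amine. In an assay on SHEP1 cells for agonist activity at Neuronal acetylcholine receptor; alpha4/beta2 (Homo sapiens), read by FLIPR and calcium flux (a higher number here means a larger maximal response, a lower number a smaller maximal response), compound 1 gives 94%, a maximal response close to that of the reference. Going by the values given here, compound 2 has the same ketone on a larger bicyclic core, but in this assay compound 2 stands at "not determined" (no result reported), so it stands without a number and no step can be placed against it.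

Compound 3 `CC(C)NC(=O)[C@H]1C[C@@H]2CNC[C@@H](C2)C1` keeps the core of compound 2 and differs only at the carbonyl carbon: isopropylamino in place of furan-2-yl on a carbonyl carbon. Without a value for compound 2, the size of this step in this assay cannot be judged from a measured pair; the expectation rests on compound 1 alone, which shows that the furan ketone supports a near-full response. Compound 3 is estimated at 60%, with a range from 20% to 100%.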

Compound 3, largest response reached (Emax), in percent of the reference or control that the assay uses: 64%
Compound 3: middle estimate off by 4 percentage points, on the low side; low and high end bracket the measured number.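

With compound 2 at "not determined" (no result reported) and compound 3 at 64% in this assay, no step can be read between them. The compounds shown leave open how isopropylamino in place of furan-2-yl changes the maximal response on a shared core. No further evidence bears on this result.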